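From Carbamoyl to Benzoyl on a Shared Core

This account rests on a few compounds, and the source may have more. Where it says the series, first, only, none or still open, it means among the compounds named here.

Of the compounds shown here, two that share a core have been tested in a functional assay on OVCAR-3 cells (Homo sapiens) for inhibition, read by sulforhodamine B assay, with a stated time of 48 h; a lower number here means a stronger inhibitor of growth, a higher number a weaker inhibitor of growth. Compound 1 `N#C/C(=C\N1CCN(C(=O)c2ccco2)C1=S)C(=O)Nc1ccc(Cl)cc1` gives 15500 nM. Compound 2 `N#C/C(=C\N1CCN(C(=O)c2ccco2)C1=S)C(N)=O` gives 19000 nM. Among the compounds with values here, compound 2 holds the higher of the two numbers, yet its only neighbour, compound 1, lies within the scatter of it, as the step of a 1.2-fold higher number from compound 1 to compound 2 (0.09 log units; within the scatter) shows, so the two cannot be told apart.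

Compound 3 `N#C/C(=C\N1CCN(C(=O)c2ccco2)C1=S)C(=O)c1ccccc1` has not been measured. It differs from compound 2 by phenyl in place of amino on a carbonyl carbon. Within the data shown here, the one measured step, a 1.2-fold higher number from compound 1 to compound 2 (0.09 log units; within the scatter), exchanged a 4-chlorophenyl for hydrogen on an amide-type nitrogen and stayed within the scatter; no measured step touches the carbonyl carbon itself. With only that to go on, no step beyond the scatter is expected in either direction. Compound 3 is therefore estimated at 17000 nM, with a range from 5000 nM to 50000 nM. That amounts to an expected step of a 1.1-fold lower number from compound 2 to compound 3 (0.05 log units; within the scatter).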

Compound 3, concentration for 50% growth inhibition: 18200 nM
Estimate against measurement, compound 3: 1.1-fold (0.03 log units) below, within the range that was stated.
By their numbers in this assay, from the lowest: compounds 1, 3 and 2 (each within the scatter of the next).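

Within the data shown here, this is the first change made at the carbonyl carbon itself, and in this assay the exchange of carbamoyl for benzoyl gives a 1.0-fold lower number from compound 2 to compound 3 (0.02 log units; within the scatter). Compound 3 has no nitrogen on that carbon, and the comparison with the anilide-type compound gives a 1.2-fold higher number from compound 1 to compound 3 (0.07 log units; within the scatter), so amino, (4-chlorophenyl)amino and phenyl on this carbonyl carbon cannot be told apart in these three compounds. Nothing available explains why these numbers stay together.

From the compounds shown here alone, it remains open whether any group on this carbonyl carbon can move the number beyond the scatter, for example a carboxylic acid or a longer alkyl chain in place of the phenyl. The rest of the shared core is identical in all three compounds, so the effect of a change there is also unknown.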